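From tert-butoxy to tert-butyl on a carbonyl carbon

The source may report more compounds than this note shows. Statements on the series, on what has been measured and on what is new or still open speak of the compounds shown alone.

In a toxicity assay on KB cells (Homo sapiens) for cytotoxicity, read by fluorescence, with a stated time of 3 days (on this read-out lower numbers stand for an effect already at smaller amounts and higher numbers for an effect only at larger amounts of compound), compound 1 `CCCCOC(=O)CNC(=O)[C@H](CSc1ccc([N+](=O)[O-])cc1[N+](=O)[O-])NC(=O)CC[C@H](NC(=O)OC)C(=O)OCCCC` reads > 300 uM and this is a limit, not a number. Going by the values given here, compound 2 `CCCCOC(=O)CNC(=O)[C@H](CSc1ccc([N+](=O)[O-])cc1[N+](=O)[O-])NC(=O)CC[C@H](NC(=O)OC(C)(C)C)C(=O)OCCCC` gives 70.4 uM as the only actual number so far. Among the compounds with values here, the single measured step is an at least 4.2-fold lower number from compound 1 to compound 2 (0.62 log units; beyond the scatter) and it put tert-butyl in place of methyl on an oxygen.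

Compound 3 `CCCCOC(=O)CNC(=O)[C@H](CSc1ccc([N+](=O)[O-])cc1[N+](=O)[O-])NC(=O)CC[C@H](NC(=O)C(C)(C)C)C(=O)OCCCC` keeps the rest of compound 2 but has tert-butyl in place of tert-butoxy on a carbonyl carbon and so retains the tert-butyl group. The measured step did not make this exchange, so its size cannot simply be carried over. The expectation therefore stays anchored on compound 2 at 70.4 uM with only a small drift towards a higher number. The expected change is a 1.3-fold higher number from compound 2 to compound 3 (0.11 log units; within the scatter) and no step beyond the scatter is anticipated in this assay here. Compound 3 is estimated at 90 uM with a likely range from 35 uM to 230 uM once it is measured.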

Compound 3, concentration for half-maximal effect: 83.4 uM
Compound 3: the middle estimate sits 1.1-fold (0.03 log units) above what was measured; low and high end bracket the measured number.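

Within this assay, exchanging tert-butoxy for tert-butyl on a carbonyl carbon whose other neighbour is an amide-type nitrogen gives a 1.2-fold higher number from compound 2 to compound 3 (0.07 log units; within the scatter), so the oxygen of the tert-butoxy group can go without a change that can be read here. The shift seen earlier therefore does not depend on that oxygen, and it reappears without it in an at least 3.5-fold lower number from compound 1 to compound 3 (0.55 log units; beyond the scatter), so both compounds that carry a tert-butyl unit, with or without the oxygen, lie beyond the scatter from compound 1. The reading of compound 1 is a limit and not a number, which leaves the true size of both steps from it unknown: the limit of > 300 uM in this assay, at which 1 of the 3 values shown sits.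

The compounds shown leave open whether a tert-butyl unit is needed at all on this carbonyl carbon, or whether an isopropyl, an ethyl or a phenyl group would give a similar reading in this assay. They also do not tell what a free amine would do at this place, with the carbonyl group and its substituent gone altogether.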